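The source may report more compounds than this note shows. Statements on the series, on what has been measured and on what is new or still open speak of the compounds shown alone.

Measured compounds:
- compound 1, `O=[N+]([O-])c1ncn(CCCNS(=O)(=O)c2cc(Cl)sc2Cl)n1`: 119000 nM
- compound 2, `Cc1csc(C(=O)NCCCn2cnc([N+](=O)[O-])n2)c1`: 173000 nM

Both numbers come from an ADME assay on L6 cells (Rattus norvegicus) for cytotoxicity, read by resazurin assay, with a stated time of 72 h; on this read-out higher numbers stand for weaker inhibition and lower numbers for stronger inhibition. Compound 2 has the higher of the two numbers, but the gap to compound 1 is within the scatter of repeated runs, so the two cannot be told apart on this read-out; both sit at the weak end of what this assay reports. For the measured compounds named here, no step between the two measured compounds is computed, since they differ in more than one place.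

The next compound, compound 3, `O=C(NCCCn1cnc([N+](=O)[O-])n1)c1ccsc1`, differs from compound 2 in one place: thiophen-3-yl in place of 4-methylthiophen-2-yl on a carbonyl carbon. The methyl group is lost and the thiophene is attached through a different ring carbon. On the two numbers available, neither of which is a single-point comparison with compound 3, there is no basis for expecting a step beyond the scatter in this assay, in either direction.

Compound 3 is therefore expected to land close to compound 2, at an estimated 180000 nM with a range of 90000 nM to 360000 nM, which means an expected step of a 1.0-fold higher number from compound 2 to compound 3 (0.02 log units; within the scatter).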

Compound 3, half-maximal inhibitory concentration: > 356000 nM
Compound 3: a limit, no number; the forecaster's own chance of this, stated with the estimate: 20%; at least 1.9-fold (0.29 log units) between middle value and limit.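

In this assay compound 3 gives > 356000 nM, which is a limit and not a number. Thiophen-3-yl in place of 4-methylthiophen-2-yl on a carbonyl carbon whose other neighbour is an amide-type nitrogen gives an at least 2.0-fold higher number from compound 2 to compound 3 (0.31 log units; beyond the scatter), so this position can shift the read-out towards weaker inhibition, something the two earlier compounds could not show, as they gave no step. The printed size is only a floor for this change, and the true size cannot be read, because one end of the step is a limit: the limit of > 356000 nM in this assay, at which 1 of the 3 values shown sits.

The change removes the methyl group and also moves the attachment to a different ring carbon, so the shift cannot be assigned to either alteration alone; plain thiophen-2-yl on the same carbonyl carbon would separate the two. Also open, going by these compounds, is how a ring other than thiophene, such as phenyl, reads at this position, and whether any group there moves the number towards stronger inhibition in this assay.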